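Isopropylamino Replaces Methyl on the Shared Core

The source may hold more compounds than are shown below. What is called first, only, known or untested is meant among the compounds shown, and "the series" means these compounds.

For the measured compounds named here, compound 2 `COc1nn(C)c2nc(C)nc(NS(=O)(=O)c3cccc(Cl)c3Cl)c12` is the weaker of the two compounds measured so far: in a functional assay on cells for antagonist activity at C-C chemokine receptor type 4 (Homo sapiens), read by GTPgammaS binding (a lower number here means a stronger inhibitor, a higher number a weaker inhibitor), compound 2 gives 631 nM, whereas compound 1 `COc1nn(CC(=O)O)c2ncnc(NS(=O)(=O)c3cccc(Cl)c3Cl)c12` gives 200 nM, a gap beyond the scatter. Compound 3 `COc1nn(C)c2nc(NC(C)C)nc(NS(=O)(=O)c3cccc(Cl)c3Cl)c12` differs from compound 2 in a single place: isopropylamino in place of methyl on an aromatic carbon. Going by the values given here, no measured pair shows this particular change, so its effect can only be guessed. The step of a 1.6-fold lower number from compound 2 to compound 3 (0.20 log units; within the scatter) is expected to be small, leaning toward slightly stronger inhibition. Compound 3 is therefore estimated at 400 nM, within a range of 100 nM to 1600 nM.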

Compound 3, half-maximal inhibitory concentration: 3160 nM
Beside the measured number, compound 3's estimate is 7.9-fold (0.90 log units) below it, and the stated range ends below it.
By their numbers in this assay, from the lowest: compound 1; then compound 2; then compound 3.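

On the aromatic carbon between two ring nitrogen atoms, isopropylamino in place of methyl gives a 5.0-fold higher number from compound 2 to compound 3 (0.70 log units; beyond the scatter) in this assay, which means weaker inhibition. This is the first single-change step among these compounds, and it shows that what sits at this position can alter inhibition by more than the usual scatter. Nothing measured here says why the number rises.

Going by these compounds, how methylamino, a plain amine or an ethyl chain would behave at this carbon remains open. The compounds shown therefore cannot separate the contribution of the nitrogen from that of the isopropyl part.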